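Amide Linker Replaces Benzyl on a Vasorelaxant Cyanoguanidine Core

A few compounds are considered here, and "the series" means these few. Any claim that something is new, unique, unknown or untested is made for them only; others in the source may bear on it.

Measured compounds:
Compound 1 `CC1(C)Oc2ccc(Cc3ccccc3)cc2[C@@H](/N=C(\NC#N)Nc2ccc(Cl)cc2)[C@@H]1O` gives 10000 nM in a functional assay (aorta) with Rattus norvegicus as the target; on this read-out lower numbers stand for stronger inhibition and higher numbers for weaker inhibition.
Compound 2 `C=C(c1ccccc1)c1ccc2c(c1)[C@@H](/N=C(\NC#N)Nc1ccc(Cl)cc1)[C@H](O)C(C)(C)O2` gives 10700 nM in this assay.
Compound 3 `CC1(C)Oc2ccc(S(=O)(=O)Nc3ccccc3)cc2[C@@H](/N=C(\NC#N)Nc2ccc(Cl)cc2)[C@@H]1O` gives 3300 nM in this assay.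

Compound 1 stands second highest of the three numbers, with compound 2 lying within the scatter of it and compound 3 giving a clearly lower number. Compound 4 `CC1(C)Oc2ccc(C(=O)Nc3ccccc3)cc2[C@@H](/N=C(\NC#N)Nc2ccc(Cl)cc2)[C@@H]1O` is not yet measured; it differs from compound 1 in one place: phenylcarbamoyl in place of benzyl on an aromatic carbon. Of the measured steps, the move to a nitrogen-linked aromatic group is the relevant one: a 3.0-fold lower number from compound 1 to compound 3 (0.48 log units; beyond the scatter), while a 1.1-fold higher number from compound 1 to compound 2 (0.03 log units; within the scatter) shows that a carbon-linked group brought no shift. The phenylcarbamoyl group likewise carries a hydrogen-bond donor and acceptor, so a modest lowering of the number in this assay is expected, a 2.5-fold lower number from compound 1 to compound 4 (0.40 log units; beyond the scatter). Compound 4 is therefore estimated at 4000 nM, within 1500 nM to 10000 nM.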

Compound 4, half-maximal inhibitory concentration: > 100000 nM
Compound 4: no number, only a limit (the forecaster's own chance of this, stated with the estimate: 10%); middle value at least 25-fold (1.39 log units) away from the limit.
By their numbers in this assay, from the lowest: compound 3; then compounds 1 and 2 (each within the scatter of the next). At a limit, above all of these: compound 4.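

In this assay compound 4 gives no number, only a limit: the limit of > 100000 nM in this assay, at which 1 of the 4 values shown sits. Going by these compounds alone, on this aromatic carbon the linker alone can matter far more than the earlier steps showed: with the phenyl ring kept, the steps are an at least 10-fold higher number from compound 1 to compound 4 (1.00 log units; beyond the scatter), an at least 9.3-fold higher number from compound 2 to compound 4 (0.97 log units; beyond the scatter) and an at least 30-fold higher number from compound 3 to compound 4 (1.48 log units; beyond the scatter). Phenylsulfamoyl and phenylcarbamoyl both hold a nitrogen, yet they move the number in opposite directions from benzyl, so that nitrogen alone does not set the read-out.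

The compounds shown leave open how a carboxylic acid or a simple amine at this position would read. Also open, from the compounds shown here alone, is whether a methyl group on the amide nitrogen would bring back a measurable number.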